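Halogen Swap on the Hydrazone Aryl of a Furan Series

The compounds below may be only part of what the source reports. "The series", "measured", "known", "first", "only" and "open" are said of these compounds alone.

Compound 2 `O=C(N/N=C/c1ccc(Cl)cc1)c1ccc(-c2ccccc2F)o1` is the lower of the two measured compounds in a functional assay on BGC-823 cells (Homo sapiens) for inhibition, read by sulforhodamine B assay, with a stated time of 48 h, tested at 10 uM (on this read-out lower numbers stand for less inhibition of growth and higher numbers for more inhibition of growth at the one concentration tested), giving 32.6%. Compound 1 `O=C(N/N=C/c1ccc(-c2cccc(F)c2)o1)c1ccc(Br)cc1` gives 46.7% in this assay, a number that stands beyond the scatter above compound 2. Compound 3 `O=C(N/N=C/c1cccc(Br)c1)c1ccc(-c2ccccc2F)o1` has not yet been measured; it differs from compound 2 by 3-bromophenyl in place of 4-chlorophenyl on a carbon with a double bond to nitrogen. Going by the values given here, no measured pair shows this change, so its size is unknown. A small shift, perhaps slightly upward and not clearly beyond the scatter, is expected, a number 3.4 percentage points higher from compound 2 to compound 3 (within the scatter). Compound 3 is therefore estimated at 36%, within a range of 20% to 52%.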

Compound 3, percent growth inhibition at one concentration: 43.6%
Compound 3: the middle estimate sits 7.6 percentage points below what was measured, and the stated range covers the measured number.
By their numbers in this assay, from the lowest: compound 2; then compounds 3 and 1 (each within the scatter of the next).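

In this assay, going by these compounds alone, this change gives a number 11 percentage points higher from compound 2 to compound 3 (beyond the scatter) and so shows that the aryl group on a carbon with a double bond to nitrogen bears on the read-out, which the earlier compounds could not show. The step replaces chlorine with bromine and moves the halogen from the 4-phenyl to the 3-phenyl position at once, so it cannot be divided between the two. No evidence bearing on the reason for this step is available. Going by these compounds, whether 3-chlorophenyl or 4-bromophenyl would separate the two parts of the change remains open, as does the effect of a 3-aminophenyl group here.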